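The source may hold more compounds than are shown below. What is called first, only, known or untested is meant among the compounds shown, and "the series" means these compounds.

Measured compounds in the series so far:

- compound 1 `Cc1ccc(C(=O)N2CCN(c3nc(=O)c4cc(C(F)(F)F)cc([N+](=O)[O-])c4s3)CC2)cc1` — 6.7 ug/mL
- compound 2 `O=C(c1ccccc1Cl)N1CCN(c2nc(=O)c3cc(C(F)(F)F)cc([N+](=O)[O-])c3s2)CC1` — 8.18 ug/mL

In a physicochemical assay for solubility, read by HPLC (on this read-out lower numbers stand for lower solubility and higher numbers for higher solubility), compound 2 stands highest of the two numbers, yet its nearest neighbour, compound 1, sits within the scatter of it, so no order can be read between the two. Among the compounds with values here, the one step that connects the measured pair, a 1.2-fold higher number from compound 1 to compound 2 (0.09 log units; within the scatter), exchanges one aromatic ring for another on the carbonyl carbon and leaves this assay essentially unmoved.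

Compound 3 `O=C(C1CC1)N1CCN(c2nc(=O)c3cc(C(F)(F)F)cc([N+](=O)[O-])c3s2)CC1` is not yet measured. Its difference from compound 2 is cyclopropyl in place of 2-chlorophenyl on a carbonyl carbon. This change is of a different kind from the measured step: the group entering is a three-membered non-aromatic ring with three heavy atoms, where the measured step kept a six-membered aromatic ring throughout. Within the data shown here, the step from compound 1 to compound 2 therefore bears on it only loosely, and it offers no precedent for removing the aromatic ring altogether.

On that thin basis a small rise is expected, a 1.8-fold higher number from compound 2 to compound 3 (0.26 log units; within the scatter), with a wide range. For compound 3 the estimate in this assay is 15 ug/mL, between 6 ug/mL and 40 ug/mL.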

Compound 3, solubility: 52.9 ug/mL
Estimate against measurement, compound 3: 3.5-fold (0.55 log units) below; the measured number lies above the stated range.
By their numbers in this assay, from the lowest: compounds 1 and 2 (each within the scatter of the next); then compound 3.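

In this assay, this place on the carbonyl carbon proves able to shift the read-out: cyclopropyl gives a 6.5-fold higher number from compound 2 to compound 3 (0.81 log units; beyond the scatter) and a 7.9-fold higher number from compound 1 to compound 3 (0.90 log units; beyond the scatter), whereas the exchange of one six-membered aromatic ring for another gave only a 1.2-fold higher number from compound 1 to compound 2 (0.09 log units; within the scatter). Compound 1 and compound 2 lie within the scatter of each other, so the two aromatic amides form one reference level, and cyclopropyl stands clear of both, with 3 heavy atoms entering in place of the 7 that leave compound 2. Nothing at hand accounts for the size of this rise.

Compound 3 loses the aromatic ring and heavy atoms in one step, so the compounds shown leave open which of the two goes with the higher number; cyclohexyl on the same carbonyl carbon would keep a six-membered ring without aromaticity and would pull the two apart. Also open is how a group carrying an amine or a carboxylic acid would read in this place, as the three compounds shown all have rings of carbon only there.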